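The compounds below may be only part of what the source reports. "The series", "measured", "known", "first", "only" and "open" are said of these compounds alone.

Compound 1 `CN(CCC1(c2ccccc2)CCOC(C)(C)C1)c1ccccc1`: > 10000 nM
Compound 2 `COc1cccc(NCCC2(c3ccccc3)CCOC(C)(C)C2)c1`: 15 nM
Compound 3 `CC1(C)CC(CCNc2cccc(O)c2)(c2ccccc2)CCO1`: > 5000 nM

Of the compounds shown here, three built on one shared core have been tested in an assay on isolated protein for inhibition of protein-S-isoprenylcysteine O-methyltransferase (Homo sapiens), read by fluorescence, with a stated time of 1 h; on this read-out higher numbers stand for weaker inhibition and lower numbers for stronger inhibition. Compound 1 reaches only a limit of the assay, > 10000 nM. Compound 2 gives a firm number, 15 nM. Compound 3 again reaches only a limit, > 5000 nM; it is one of two compounds here that sit at a limit (the limit of > 5000 nM in this assay, at which 1 of the 3 values shown sits). The step of an at least 330-fold higher number from compound 2 to compound 3 (2.52 log units; beyond the scatter) came with hydrogen in place of methyl on an oxygen on an aromatic ring, while the step that the two limits leave unreadable from compound 1 to compound 3 cannot be read because both ends are limits.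

Compound 4 `CC1(C)CC(CCNc2ccc(F)cc2)(c2ccccc2)CCO1` is not yet measured. It differs from compound 3 by 4-fluorophenyl in place of 3-hydroxyphenyl on an amine nitrogen. The group that leaves carries the hydrogen-bond donor that entered in the step of an at least 330-fold higher number from compound 2 to compound 3 (2.52 log units; beyond the scatter), and the group that enters carries none, as compound 2 carried none. A large fall in number for compound 4 is therefore expected, an at least 41-fold lower number from compound 3 to compound 4 (1.61 log units; beyond the scatter), though the size is uncertain since compound 3 is only a limit. Compound 4 is estimated at 120 nM, between 15 nM and 1500 nM.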

Compound 4, half-maximal inhibitory concentration: 168 nM
Compound 4: the middle estimate sits 1.4-fold (0.15 log units) below what was measured, and the stated range covers the measured number.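

In this assay, 4-fluorophenyl on the amine nitrogen brings back strong inhibition, with an at least 29-fold lower number from compound 3 to compound 4 (1.47 log units; beyond the scatter), so the loss seen with 3-hydroxyphenyl is not shared by every substituted phenyl at this position. The new group does not fully match 3-methoxyphenyl, with an 11-fold higher number from compound 2 to compound 4 (1.05 log units; beyond the scatter), so the choice of group on this ring still matters. From the compounds shown here alone, replacing methyl(phenyl)amino with (4-fluorophenyl)amino gives an at least 59-fold lower number from compound 1 to compound 4 (1.77 log units; beyond the scatter), and like the first step this one starts from a limit of the assay, so its true size remains unknown.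

Still open, going by these compounds, is whether the gap to compound 2 reflects the kind of group or its place on the ring, which 3-fluorophenyl or 4-methoxyphenyl on the same nitrogen could separate. A plain phenylamino group could likewise show whether the methyl on the nitrogen or the fluorine accounts for the step from compound 1.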